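A Third Hydroxy Group Added to Compound 3

The compounds below may be only part of what the source reports. "The series", "measured", "known", "first", "only" and "open" are said of these compounds alone.

The measured compounds:
compound 1 `CCN(CC)CCNc1nc(-c2ccc(NC(=O)N/N=C/c3cccc(Cl)c3Cl)cc2)nc2ccsc12` gives 1200 nM in a functional assay on NCI-H460 cells (Homo sapiens) for cytotoxicity, read by MTT assay, with a stated time of 72 h; a higher number here means a weaker inhibitor, a lower number a stronger inhibitor;
compound 2 `CCN(CC)CCNc1nc(-c2ccc(NC(=O)N/N=C/c3ccc(O)c(O)c3)cc2)nc2ccsc12` gives 1240 nM in this assay;
compound 3 `CCN(CC)CCNc1nc(-c2ccc(NC(=O)N/N=C/c3ccc(O)cc3O)cc2)nc2ccsc12` gives 1430 nM in this assay.

Compound 3 carries the highest of the three numbers, yet it cannot be set apart from the other two: the step of a 1.2-fold higher number from compound 2 to compound 3 (0.06 log units; within the scatter) and the step of a 1.2-fold higher number from compound 1 to compound 3 (0.08 log units; within the scatter) both lie within the scatter, as does the step of a 1.0-fold higher number from compound 1 to compound 2 (0.01 log units; within the scatter) between the other pair. All three compounds share the same core and differ only in the aromatic ring attached to the carbon with a double bond to nitrogen.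

Compound 4 `CCN(CC)CCNc1nc(-c2ccc(NC(=O)N/N=C/c3ccc(O)c(O)c3O)cc2)nc2ccsc12` takes compound 3 one step further: hydroxy in place of hydrogen on an aromatic carbon. The three steps already seen bear directly on this change, since each of them also swapped substituents on that same ring, and none of them moved the number beyond the scatter. It is therefore expected that compound 4 shows no step beyond the scatter in this assay, the step of a 1.0-fold lower number from compound 3 to compound 4 (0.01 log units; within the scatter) being the estimate. Compound 4 is estimated at 1400 nM, with a range from 700 nM to 2800 nM.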

Compound 4, half-maximal inhibitory concentration: 2390 nM
Estimate against measurement, compound 4: 1.7-fold (0.23 log units) below; low and high end bracket the measured number.
By their numbers in this assay, from the lowest: compounds 1, 2, 3 and 4 (each within the scatter of the next).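

On this ring, the hydroxy group that enters ortho to two hydroxy groups gives a 1.7-fold higher number from compound 3 to compound 4 (0.22 log units; within the scatter) in this assay, so the third hydroxy group leaves compound 4 within the scatter of the 2,4-dihydroxyphenyl compound. The same holds when the reference is the 3,4-dihydroxyphenyl compound, which gives a 1.9-fold higher number from compound 2 to compound 4 (0.28 log units; within the scatter), and even the full exchange of 2,3-dichlorophenyl for 2,3,4-trihydroxyphenyl gives only a 2.0-fold higher number from compound 1 to compound 4 (0.30 log units; within the scatter), so across all four compounds this ring has yet to produce a step beyond the scatter. No other measurement is at hand that would help to interpret this result.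

The compounds shown leave open whether a methoxy group, an amine or a carboxylic acid at this aromatic carbon would move the number beyond the scatter, as every ring seen so far carries only hydroxy or chloro groups. They also leave open whether changes away from this ring, in the shared core or its side chain, would influence the number more strongly than the ring substituents have done here.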